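A Hydroxyphenyl for Methoxyphenyl Swap Repeated on a Second Core

A few compounds are considered here, and "the series" means these few. Any claim that something is new, unique, unknown or untested is made for them only; others in the source may bear on it.

Compound 1 `O=C1O[C@H]([C@@H](O)Cn2cc(-c3cccc(O)c3)nn2)C(OCc2ccccc2)=C1OCc1ccccc1` in a functional assay on MCF7 cells (Homo sapiens) for antiproliferative activity, read by MTT assay, with a stated time of 72 h; on this read-out higher numbers stand for weaker inhibition and lower numbers for stronger inhibition: 51800 nM
Compound 2 `COc1ccccc1-c1cn(C[C@H](O)[C@H]2OC(=O)C(OCc3ccccc3)=C2OCc2ccccc2)nn1` in this assay: > 100000 nM, which is a limit of the assay and not a number
Compound 3 `COc1ccccc1-c1cn(C/C=C2\OC(=O)C(OCc3ccccc3)=C2OCc2ccccc2)nn1` in this assay: > 100000 nM, which is again a limit and not a number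

Only compound 1 gives a number in this assay. Within the data shown here, the one measured step, an at least 1.9-fold lower number from compound 2 to compound 1 (0.28 log units; that floor lies within the scatter), is the change (3-hydroxyphenyl in place of 2-methoxyphenyl on an aromatic carbon). Its size can only be read as a floor, resting on (the limit of > 100000 nM in this assay, at which 2 of the 3 values shown sit). How the core of compound 3 differs from the core of compound 2 is not broken down here.

Compound 4 `O=C1O/C(=C\Cn2cc(-c3cccc(O)c3)nn2)C(OCc2ccccc2)=C1OCc1ccccc1` remains to be measured in this assay. It carries the same change as before, (3-hydroxyphenyl in place of 2-methoxyphenyl on an aromatic carbon), now made on the core of compound 3. Since compound 3 sits at the limit, the expected step is an at least 1.6-fold lower number from compound 3 to compound 4 (0.22 log units; that floor lies within the scatter). Compound 4 is thus estimated at 60000 nM, between 20000 nM and 150000 nM, with a real chance that only a limit is reported.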

Compound 4, half-maximal inhibitory concentration: 27800 nM
Compound 4: the middle estimate sits 2.2-fold (0.33 log units) above what was measured; the range from low to high includes it.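

In this assay, the change to 3-hydroxyphenyl in place of 2-methoxyphenyl again goes with a lower number on the second core, a step of an at least 3.5-fold lower number from compound 3 to compound 4 (0.55 log units; beyond the scatter). This shows that the direction of the change carries over to the core of compound 3, and set beside the first core the picture is this: the same change on two cores in this assay, an at least 1.9-fold lower number (0.28 log units; that floor lies within the scatter) from compound 2 to compound 1 and an at least 3.5-fold lower number (0.55 log units; beyond the scatter) from compound 3 to compound 4; the limit leaves it open whether they differ Both steps are only floors, so the series does not show whether the change is worth the same on the two cores: the limit of > 100000 nM in this assay, at which 2 of the 4 values shown sit.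

The compounds shown leave open what the hydroxyl itself contributes. They also do not say whether an amine or a carboxylic acid in its place on the phenyl ring would go with a lower number on either core.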